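The source may hold more compounds than are shown below. What is called first, only, known or untested is meant among the compounds shown, and "the series" means these compounds.

Measured compounds in an assay on Sf9 cells for inhibition of inhibitor of nuclear factor kappa-B kinase subunit epsilon (Homo sapiens), read by ADP-Glo, with a stated time of 60 min; a higher number here means a weaker inhibitor, a lower number a stronger inhibitor:
- compound 1 `Cc1[nH]nc(N)c1-c1ccc(Cl)c(Cl)c1` gives > 100000 nM, which is a limit of the assay and not a number.
- compound 2 `CC(=O)n1nc(N)c(-c2ccc(Cl)c(Cl)c2)c1C` gives > 100000 nM, again a limit.
- compound 3 `Cc1c(-c2ccc(Cl)c(Cl)c2)c(N)nn1C(=O)C1CCC1` gives > 100000 nM, again a limit.

Compound 1 thus stands only at a limit in this assay; no number has been read for it, and the same holds for the other two compounds, so that the limit of > 100000 nM in this assay, at which 3 of the 3 values shown sit, is the whole of the evidence in hand. The steps from compound 1 to compound 2 a step that the two limits leave unreadable from compound 1 to compound 2 and from compound 1 to compound 3 a step that the two limits leave unreadable from compound 1 to compound 3 cannot be sized, and nor can the step from compound 2 to compound 3 a step that the two limits leave unreadable from compound 2 to compound 3: two limits give no readable difference.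

Compound 4 `Cc1[nH]nc(NC(=O)C(F)(F)F)c1-c1ccc(Cl)c(Cl)c1` differs from compound 1 by (trifluoromethyl)carbonyl in place of hydrogen on a nitrogen on an aromatic ring. For the measured compounds named here, none of the measured steps touches this nitrogen; the two acyl changes seen so far sit on an aromatic nitrogen of the ring and leave both partners at the limit, so they bear on the new step only in showing that acylation of the shared core has not produced a readable number anywhere.

The expected step from compound 1 to compound 4 is therefore a number no higher from compound 1 to compound 4 (the limit leaves the size open), with no direction that the data can support. Compound 4 is estimated at 100000 nM, range 30000 nM to 300000 nM, most likely reported again as a limit.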

Compound 4, half-maximal inhibitory concentration: > 100000 nM
Compound 4 was reported as a limit (the forecaster's own chance of this, stated with the estimate: 85%); the middle value lies on the limit itself.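

In this assay compound 4 gives > 100000 nM as a limit of the assay and not a number. For the compounds shown here, with compound 1 also at a limit, no step from compound 1 to compound 4 can be read. Still open is whether any change to the shared core gives a readable number in this assay as the record stands at one limit: the limit of > 100000 nM in this assay, at which 4 of the 4 values shown sit.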